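This account rests on a few compounds, and the source may have more. Where it says the series, first, only, none or still open, it means among the compounds named here.

For the measured compounds named here, compound 1 `CCCCOC(=O)Nc1ccc(S(=O)(=O)N2C[C@H](c3ccccc3)NC2=O)cc1CC` holds the only number in the set: in a functional assay on NCI-H460 cells (Homo sapiens) for cytotoxicity, read by MTT assay (a lower number here means a stronger inhibitor, a higher number a weaker inhibitor), compound 1 gives 200 nM. Compound 2 `Cc1cc(S(=O)(=O)N2C(=O)N[C@@H](c3ccccc3)C2C)ccc1NC(=O)c1ccc([N+](=O)[O-])cc1` stops at a limit of this assay, compound 2 giving > 10000 nM. Compound 3 `CC1[C@H](c2ccccc2)NC(=O)N1S(=O)(=O)c1ccc(NC(=O)c2ccc([N+](=O)[O-])cc2)c(Cl)c1` also stops at a limit, compound 3 giving > 10000 nM. Going by the values given here, the one measured single-point step, a step that the two limits leave unreadable from compound 2 to compound 3, cannot be sized because both of its ends sit at the limit of > 10000 nM in this assay, at which 2 of the 3 values shown sit.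

Compound 4 `CCc1cc(S(=O)(=O)N2C[C@H](c3ccccc3)NC2=O)ccc1NC(=O)c1ccc(N)cc1` differs from compound 1 by 4-aminophenyl in place of butoxy on a carbonyl carbon. Among the compounds with values here, no measured step touches the carbonyl carbon; the step from compound 2 to compound 3 changes an aromatic substituent elsewhere and is unreadable anyway. Compound 2 and compound 3 both bear an aromatic carbonyl on the same amide nitrogen where compound 1 bears butoxycarbonyl, and both sit at the limit, but each also differs from compound 1 in the core, so nothing here isolates the change at the carbonyl. The expectation is therefore a loss in this assay, with wide uncertainty. Compound 4 is expected at 1500 nM, within 300 nM to 10000 nM. The step of a 7.5-fold higher number from compound 1 to compound 4 (0.88 log units; beyond the scatter) is the expected size, with a real chance that only a limit is returned.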

Compound 4, half-maximal inhibitory concentration: 670 nM
Beside the measured number, compound 4's estimate is 2.2-fold (0.35 log units) above it, and the stated range covers the measured number.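

Putting 4-aminophenyl in place of butoxy on the carbonyl carbon gives a 3.4-fold higher number from compound 1 to compound 4 (0.53 log units; beyond the scatter) in this assay, a modest loss. For the compounds shown here, this is the first readable change at this carbonyl carbon: with the rest of the structure held constant, an aromatic group on the carbonyl still returns a measured value and not a limit, so the butoxy chain is not required for a measurable effect in the shared core. Compound 2 and compound 3 differ from compound 4 in more than one place, so they cannot be set against it, and the step between them cannot be read: the limit of > 10000 nM in this assay, at which 2 of the 4 values shown sit.

Still open, as far as these compounds go, is whether the amine of the 4-aminophenyl group matters to this value or the aromatic ring alone sets it; a plain phenyl, a carboxylic acid in place of the amine, or a longer alkoxy chain than butoxy would separate these readings. Also open, from the compounds shown here alone, is whether the step seen here would hold in a core other than that of compound 1.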